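Benzylthiazole carboxamides: methoxy to chloro on the pendant phenyl

A few compounds are considered here, and "the series" means these few. Any claim that something is new, unique, unknown or untested is made for them only; others in the source may bear on it.

Measured compounds:
compound 1, `Cc1nc(Cc2cccc(C(F)(F)F)c2)sc1-c1ccc(C(N)=O)c(C(C)C)c1`, 370 nM in a functional assay on cells for agonist activity at G-protein coupled receptor 52 (Homo sapiens), read by AlphaScreen and cAMP accumulation, with a stated time of 30 min; a lower number here means that less compound is needed, a higher number that more compound is needed for the effect
compound 2, `COc1cccc(Cc2nc(C)c(-c3ccc(C(N)=O)c(C)c3)s2)c1`, 160 nM in this assay

Of the two numbers in hand, compound 2 gives the lowest, with 160 nM in this assay; compound 1 gives 370 nM, a gap beyond the usual scatter of this assay. Compound 1 and compound 2 differ in more than one place, so no single step can be read from that pair.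

Compound 3, `Cc1cc(-c2sc(Cc3cccc(Cl)c3)nc2C)ccc1C(N)=O`, is the next compound and has not yet been measured in this assay. It differs from compound 2 in one place: chloro in place of methoxy on an aromatic carbon. Cut one bond further out, the change reads 3-methoxyphenyl to 3-chlorophenyl, on an aromatic carbon of a six-membered aromatic ring of carbon only, meta to a large group.

Within the data shown here, no measured step covers a methoxy-to-chloro swap, so the size of the step is unknown. The expectation is for a small step only, from compound 2 to compound 3 of a 1.3-fold higher number from compound 2 to compound 3 (0.10 log units; within the scatter), toward a slightly higher number and likely within the scatter. Compound 3 is accordingly estimated at 200 nM, with a range of 70 nM to 600 nM in this assay.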

Compound 3, half-maximal effective concentration: 130 nM
The estimate for compound 3 lay 1.5-fold (0.19 log units) above the measured number, and the stated range covers the measured number.
By their numbers in this assay, from the lowest: compounds 3 and 2 (each within the scatter of the next); then compound 1.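

In this assay, among these compounds, the change from 3-methoxyphenyl to 3-chlorophenyl provides the first single-place step, a 1.2-fold lower number from compound 2 to compound 3 (0.09 log units; within the scatter), so this place on the aromatic ring accepts chloro in place of methoxy with no readable shift in the number. Methoxy counts as a hydrogen-bond acceptor and chloro does not, yet the two numbers remain within the scatter, so this pair gives no sign that an acceptor is required at this place. Nothing at hand bears on why the two numbers lie so close.

From the compounds shown here alone, whether an amine, a carboxylic acid or a nitrile at this same place would also stay within the scatter remains open, as does the outcome with a plain hydrogen there. Going by these compounds, the step also rests on a single pair, so it is unknown whether the same swap would read the same way on the core of compound 1, or with chloro moved elsewhere on the aromatic ring.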